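This account rests on a few compounds, and the source may have more. Where it says the series, first, only, none or still open, it means among the compounds named here.

Series notes. In an assay on isolated protein for binding affinity to 5-hydroxytryptamine receptor 3A (Homo sapiens) (on this read-out higher numbers stand for weaker inhibition and lower numbers for stronger inhibition), compound 1 `CC(=O)N1CCN(CCN2CCC(CNC(=O)c3cccc4[nH]c(C(C)C)nc34)CC2)CC1` gives 39800 nM. Compound 3 `CS(=O)(=O)N1CCN(CC(O)CN2CCC(NC(=O)c3cccc4[nH]cnc34)CC2)CC1` gives 63100 nM. Compound 2 `CCc1nc2c(C(=O)NCC3CCN(CC(O)CN4CCN(S(C)(=O)=O)CC4)CC3)cccc2[nH]1` gives 79400 nM, the highest of the three numbers, yet its gap to compound 3 and its gap to compound 1 both lie within the scatter, so the three compounds read as one level of weak binding in this assay. Compound 4 `CC(C)(C)c1nc2c(C(=O)NCC3CCN(CC(O)CN4CCN(S(C)(=O)=O)CC4)CC3)cccc2[nH]1` is not yet measured. It differs from compound 2 by tert-butyl in place of ethyl on an aromatic carbon. Within the data shown here, no measured pair isolates this change, and the three numbers point in no direction. The expected step, a 1.0-fold higher number from compound 2 to compound 4 (0.00 log units; within the scatter), is therefore taken to stay within the scatter. Compound 4 is estimated at 80000 nM, in the range 30000 nM to 200000 nM.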

Compound 4, inhibition constant: 39800 nM
The estimate for compound 4 lay 2.0-fold (0.30 log units) above the measured number, and the stated range covers the measured number.
By their numbers in this assay, from the lowest: compounds 1, 4, 3 and 2 (each within the scatter of the next).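

In this assay, among these compounds, the pair gives the first direct reading at this position: a 2.0-fold lower number from compound 2 to compound 4 (0.30 log units; within the scatter) for tert-butyl in place of ethyl on the aromatic carbon between two ring nitrogen atoms. A larger alkyl group here therefore leaves the series at the same level of weak binding, with no step beyond the scatter. No supporting data on hand explain this result. As far as these compounds go, whether a phenyl ring, an amine or a carboxylic acid on this carbon would shift the number beyond the scatter remains open. So does whether any change at this position can do so.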